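A Benzyl Swap in a Weakly Active Series

This account rests on a few compounds, and the source may have more. Where it says the series, first, only, none or still open, it means among the compounds named here.

In a functional assay on MCF7 cells (Homo sapiens) for antiproliferative activity, read by MTT assay (a higher number here means a weaker inhibitor, a lower number a stronger inhibitor), compound 1 (`COc1ccc(-n2cc(COc3ccc(/C=C/C(=O)c4cc5c(cc4O)OC(C)(C)CC5)cc3)nn2)c([N+](=O)[O-])c1`) gives "not active" (no number reported) and so has no single number to stand on. Compound 3 (`Cc1ccc(-n2cc(COc3ccc(/C=C/C(=O)c4ccc5c(c4O)CCC(C)(C)O5)cc3)nn2)cc1Br`) also gives "not active" (no number reported) and has no number either. Compound 2 (`Cc1c(-n2cc(COc3ccc(/C=C/C(=O)c4ccc5c(c4O)CCC(C)(C)O5)cc3)nn2)cccc1[N+](=O)[O-]`) gives 145000 nM as the only figure available. Compound 4 (`CC1(C)CCc2cc(C(=O)/C=C/c3ccc(OCc4cn(Cc5ccc([N+](=O)[O-])cc5)nn4)cc3)c(O)cc2O1`) departs from compound 1 by one change, (4-nitrobenzyl in place of 4-methoxy-2-nitrophenyl on an aromatic nitrogen), which puts 4-nitrobenzyl in place of 4-methoxy-2-nitrophenyl on an aromatic nitrogen. Among the compounds with values here, no measured pair shows the effect of such a change. Within the data shown here, with compound 2 at 145000 nM as the only guide, a small step toward stronger inhibition in this assay is expected, no more than a move from no number to a weak one. The estimated value for compound 4 is 70000 nM within a range of 15000 nM to 200000 nM if a number is reported at all.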

Compound 4, half-maximal inhibitory concentration: "not active" (no number reported)
For compound 4 the study gives words and no number, and the estimate cannot be compared.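

In this assay compound 1 and compound 4 are both reported as not active without a number, and no step can be read between them. Nothing shown bears on this result. On these data alone, what 4-nitrobenzyl in place of 4-methoxy-2-nitrophenyl does to a measurable potency remains open.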